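Exposure of an ozonide series after an oral dose

A few compounds are considered here, and "the series" means these few. Any claim that something is new, unique, unknown or untested is made for them only; others in the source may bear on it.

Of the compounds shown here, three sharing one core have been measured in an ADME assay on the whole organism (strain FVB) for pharmacokinetics, with Mus musculus as the target, read by LC-MS, at a dose of 30 mg/kg by the oral route; a higher number here means more compound in the circulation at the dose given, a lower number less compound in the circulation. Compound 1 `c1cc([C@H]2CC[C@]3(CC2)OOC2(O3)C3CC4CC(C3)CC2C4)ccc1OCCOC1CCNCC1` gives 9180 ng.h/mL and stands second highest of the three numbers. Compound 2 `CC(C)(N)CCOc1ccc([C@H]2CC[C@]3(CC2)OOC2(O3)C3CC4CC(C3)CC2C4)cc1` gives 12300 ng.h/mL, and the step of a 1.3-fold higher number from compound 1 to compound 2 (0.13 log units; within the scatter) lies within the scatter. Compound 3 `c1cc([C@H]2CC[C@]3(CC2)OOC2(O3)C3CC4CC(C3)CC2C4)ccc1OCC1CCNCC1` gives 4040 ng.h/mL; the step of a 2.3-fold lower number from compound 1 to compound 3 (0.36 log units; beyond the scatter) and the step of a 3.0-fold lower number from compound 2 to compound 3 (0.48 log units; beyond the scatter) are both modest and beyond the scatter.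

Compound 4 `CC1(C)CC(O)(COc2ccc([C@H]3CC[C@]4(CC3)OOC3(O4)C4CC5CC(C4)CC3C5)cc2)CC(C)(C)N1` has not yet been measured. It differs from compound 1 in one place: 4-hydroxy-2,2,6,6-tetramethylpiperidin-4-yl in place of ((piperidin-4-yl)oxy)methyl on a saturated chain carbon bound to an oxygen on an aromatic ring. Among the measured compounds shown here, two measured steps bear on this. The change from compound 1 to compound 3 shortens the side chain and removes one oxygen, and it lowered the number; the change from compound 1 to compound 2 exchanges the piperidinyloxy group for an open amine and left the number within the scatter. Compound 4 shortens the chain as compound 3 does, yet adds a hydroxyl and four methyl groups to the ring, so a modest drop is expected rather than a large one. The step of a 1.5-fold lower number from compound 1 to compound 4 (0.18 log units; within the scatter) is therefore the expected outcome in this assay. Compound 4 is estimated to give 6000 ng.h/mL, with a range from 2000 ng.h/mL to 18000 ng.h/mL.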

Compound 4, area under the concentration-time curve: 17300 ng.h/mL
For compound 4 the middle estimate is 2.9-fold (0.46 log units) below the measured one, and the stated range covers the measured number.
By their numbers in this assay, from the lowest: compound 3; then compounds 1, 2 and 4 (each within the scatter of the next).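

In this assay the 4-hydroxy-2,2,6,6-tetramethylpiperidin-4-yl group, on a saturated chain carbon bound to an oxygen on an aromatic ring, reads well clear of the unsubstituted ring at the same place, with a 4.3-fold higher number from compound 3 to compound 4 (0.63 log units; beyond the scatter) as a modest step that changes only the substituents on that ring. The short attachment at this position therefore does not by itself bring the low number of compound 3, and the new group cannot be told apart from the two longer side chains, as a 1.9-fold higher number from compound 1 to compound 4 (0.28 log units; within the scatter) and a 1.4-fold higher number from compound 2 to compound 4 (0.15 log units; within the scatter) both show. Nothing measured here gives a reason for this result.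

A 4-hydroxypiperidin-4-yl group and a 2,2,6,6-tetramethylpiperidin-4-yl group at the same place would separate the hydroxyl from the four methyl groups, and the compounds shown leave that split open. Also open, from the compounds shown here alone, is how a carboxylic acid on this side chain, or a longer chain carrying the same substituted ring, would read in this assay on the shared core.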